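Adding a second prenyl-extended arm to a symmetric core

The source may hold more compounds than are shown below. What is called first, only, known or untested is meant among the compounds shown, and "the series" means these compounds.

Values so far in a functional assay on U-373MG ATCC cells for inhibition, with U373 MG (Homo sapiens) as the target, read by MTT assay, with a stated time of 72 h; a lower number here means a stronger inhibitor of growth, a higher number a weaker inhibitor of growth ( lower means stronger ):

- compound 1 (`CC(C)=CC(=O)NC(=N)NC(=O)C=C(C)C`) gives 45600 nM
- compound 2 (`CC(C)=CCC/C(C)=C/C(=O)NC(=N)NC(=O)C=C(C)C`) gives 36200 nM

Compound 2 (36200 nM) stands level with compound 1 (45600 nM), since the two lie within the usual scatter of repeated measurements. Going by the values given here, with only two numbers, neither can be ranked above the other.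

The next compound, compound 3 (`CC(C)=CCC/C(C)=C/C(=O)NC(=N)NC(=O)/C=C(\C)CCC=C(C)C`), differs from compound 2 by one change: 3-methylbut-2-en-1-yl in place of hydrogen on a saturated chain carbon bound to a double-bonded chain carbon ( 3-methylbut-2-en-1-yl in place of hydrogen on a saturated chain carbon bound to a double-bonded chain carbon ). The same exchange has been measured exactly once, so a single step bears on this one: a 1.3-fold lower number from compound 1 to compound 2 (0.10 log units; within the scatter) ( within the scatter ). One small step is thin evidence, and nothing yet shows whether a repeat of the exchange behaves the same way. No step beyond the scatter is therefore expected in this assay, with at most a slight drift toward a lower number. The estimate is a 1.3-fold lower number from compound 2 to compound 3 (0.11 log units; within the scatter) ( an expected step, not a measured one ). Compound 3 is expected at 28000 nM ( estimated range 12000 nM to 55000 nM).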

Compound 3, concentration for 50% growth inhibition: 38900 nM
The estimate for compound 3 lay 1.4-fold (0.14 log units) below the measured number; low and high end bracket the measured number.
By their numbers in this assay, from the lowest: compounds 2, 3 and 1 (each within the scatter of the next).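

In this assay, the exchange of hydrogen for 3-methylbut-2-en-1-yl on a saturated chain carbon bound to a double-bonded chain carbon now has a second reading (a 1.1-fold higher number from compound 2 to compound 3 (0.03 log units; within the scatter)) to set beside the first (a 1.3-fold lower number from compound 1 to compound 2 (0.10 log units; within the scatter)). Both steps lie within the scatter, so adding this group a second time leaves the number as flat as the first addition did, and the slight drift that one small step seemed to hint at does not carry through to compound 3. Nothing measured here accounts for this flat behaviour.

As far as these compounds go, whether an amine, a carboxylic acid or a longer chain in place of this group would move the number beyond the scatter remains open. The picture also rests on just two steps in a single cell line, so it cannot yet be said whether the same exchange would stay as flat in other cells.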